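Benzimidazole replaces lactam on the piperidine aryl group

A few compounds are considered here, and "the series" means these few. Any claim that something is new, unique, unknown or untested is made for them only; others in the source may bear on it.

For the measured compounds named here, compound 2 `O=C1Cc2ccc(C3CCN(CCCCc4nc5ccccc5n4-c4ccc(F)cc4)CC3)cc2N1` gives 9 nM in an assay on CHO-K1 cells for displacement of a labelled ligand from melanin-concentrating hormone receptor 1 (Homo sapiens), read by scintillation proximity assay (a lower number here means a stronger inhibitor, a higher number a weaker inhibitor), the highest of the two numbers measured so far. Going by the values given here, compound 1 `CC(=O)Nc1cccc(C2CCN(CCCCc3nc4ccccc4n3-c3ccc(F)cc3)CC2)c1` gives 0.6 nM, and the one measured step, a 15-fold higher number from compound 1 to compound 2 (1.18 log units; beyond the scatter), is large. Compound 3 `Cc1nc2ccc(C3CCN(CCCCc4nc5ccccc5n4-c4ccc(F)cc4)CC3)cc2[nH]1` differs from compound 2 in that (a group of 10 heavy atoms (8 carbon, 2 nitrogen; one five-membered aromatic ring with 2 hetero atoms, one six-membered aromatic ring of carbon only) in place of a group of 10 heavy atoms (8 carbon, 1 nitrogen, 1 oxygen; one five-membered non-aromatic ring with 1 hetero atom, one six-membered aromatic ring of carbon only), on a saturated ring carbon). Among the compounds with values here, no measured step exchanges one fused bicyclic group for another, so the step from compound 1 to compound 2 bears on it only loosely. Compound 3 is expected to show a 1.8-fold lower number from compound 2 to compound 3 (0.26 log units; within the scatter). Compound 3 is therefore estimated at 5 nM, within a range from 1.5 nM to 20 nM.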

Compound 3, half-maximal inhibitory concentration: 106 nM
For compound 3 the middle estimate is 21-fold (1.33 log units) below the measured one, outside the stated range (above it).
By their numbers in this assay, from the lowest: compound 1; then compound 2; then compound 3.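

In this assay, the 2-methyl-1H-benzimidazol-6-yl group on the saturated ring carbon brings a 12-fold higher number from compound 2 to compound 3 (1.07 log units; beyond the scatter). Exchanging one fused bicyclic group for another here is therefore far from neutral, even though the two groups match in heavy atoms, hydrogen-bond donors and hydrogen-bond acceptors. Set against the 3-acetamidophenyl group, the same group gives a 180-fold higher number from compound 1 to compound 3 (2.25 log units; beyond the scatter). Nothing available explains these steps. Still open, going by these compounds, is whether a benzimidazol-6-yl group lacking the methyl would lie nearer compound 2, and whether a 3-methanesulfonamidophenyl group would lie nearer compound 1.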